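A few compounds are considered here, and "the series" means these few. Any claim that something is new, unique, unknown or untested is made for them only; others in the source may bear on it.

Measured compounds:
- compound 1 `CC(C)(C)Nc1ncnc2c1ncn2Cc1ccccc1F`, in a functional assay on the whole organism with Rattus norvegicus as the target, in the maximal electroshock model (on this read-out higher numbers stand for an effect only at larger amounts of compound and lower numbers for an effect already at smaller amounts), a limit of the assay only: > 50 mg/kg
- compound 2 `Fc1ccccc1Cn1cnc2c(NC3CCCC3)ncnc21`, 8 mg/kg
- compound 3 `CN(C)c1ncnc2c1ncn2Cc1ccccc1`, 6 mg/kg

Compound 3 holds the lowest of the two numbers given, though its gap to compound 2 lies within the scatter, so no order between the two can be drawn. For the measured compounds named here, the one step measured between these compounds is an at least 6.2-fold lower number from compound 1 to compound 2 (0.79 log units; beyond the scatter), and it is reported as a lower bound only because of the limit of > 50 mg/kg in this assay, at which 1 of the 3 values shown sits.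

Compound 4 `CN(C)c1ncnc2c1ncn2Cc1ccccc1F` differs from compound 3 by fluoro in place of hydrogen on an aromatic carbon. Going by the values given here, no measured step concerns this change: the single step on record swaps one alkyl group for another on the ring nitrogen and says nothing about a fluoro. Compound 2 carries this fluoro and compound 3 does not, but their two values sit within the scatter of each other, which is all that can be read from them. The expected step of no change at the digits printed from compound 3 to compound 4 (within the scatter) is therefore none beyond the scatter. Compound 4 is estimated at 6 mg/kg, with a range from 2 mg/kg to 18 mg/kg.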

Compound 4, dose for half-maximal effect: 8.8 mg/kg
Estimate against measurement, compound 4: 1.5-fold (0.17 log units) below; the range from low to high includes it.
By their numbers in this assay, from the lowest: compounds 3, 2 and 4 (each within the scatter of the next). At a limit, above all of these: compound 1.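

With the rest of the molecule held constant, fluoro in place of hydrogen on an aromatic carbon, ortho to a large group, gives in this assay a 1.5-fold higher number from compound 3 to compound 4 (0.17 log units; within the scatter), so this position takes the fluoro without a step that can be told from the scatter. With the fluoro kept, dimethylamino in place of cyclopentylamino gives a 1.1-fold higher number from compound 2 to compound 4 (0.04 log units; within the scatter), while dimethylamino in place of (tert-butyl)amino gives an at least 5.6-fold lower number from compound 1 to compound 4 (0.75 log units; beyond the scatter). That last step is a lower bound only, since compound 1 stands at a limit of the assay: the limit of > 50 mg/kg in this assay, at which 1 of the 4 values shown sits.

Going by these compounds, whether chloro, methoxy or a nitrile on the same aromatic carbon would give a step beyond the scatter remains open. Also open, on these data alone, is how an unsubstituted amino group or a morpholine in place of dimethylamino would read.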